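The compounds below may be only part of what the source reports. "The series", "measured", "known", "first", "only" and "open" are said of these compounds alone.

Working notes on the series in a functional assay on J774 cells (Mus musculus) for cytotoxicity, read by resazurin assay, with a stated time of 72 h; a higher number here means a weaker inhibitor, a lower number a stronger inhibitor. Compound 1 `CN(c1cccc(CO)c1)S(=O)(=O)c1ccc(-c2ccc(Cl)cc2Cl)cc1` gives 2200 nM. Compound 2 `O=S(=O)(Nc1cccc(CO)c1)c1ccc(-c2ccc(Br)cc2)cc1` gives 2500 nM. Compound 3 `O=S(=O)(Nc1cccc(CO)c1)c1ccc(-c2ccc(Br)cc2F)cc1` gives 1000 nM, the lowest of the three numbers; compound 1 is the nearest and compound 2 the furthest, both gaps beyond the scatter. For the measured compounds named here, the only single-point step measured so far is a 2.5-fold lower number from compound 2 to compound 3 (0.40 log units; beyond the scatter), a modest shift.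

Compound 4 `CN(C)c1ccc(-c2ccc(S(=O)(=O)Nc3cccc(CO)c3)cc2)cc1` differs from compound 3 by 4-(dimethylamino)phenyl in place of 4-bromo-2-fluorophenyl on an aromatic carbon. Going by the values given here, no measured step covers this exchange. Among the compounds with values here, the one step on the same ring, a 2.5-fold lower number from compound 2 to compound 3 (0.40 log units; beyond the scatter), shows that a single change there moves the number beyond the scatter, and compound 4 retains neither the fluorine nor the bromine of compound 3. Compound 2, without the fluorine, gives 2500 nM. For compound 4 the expected step is a 3.0-fold higher number from compound 3 to compound 4 (0.48 log units; beyond the scatter), toward a higher number, with wide uncertainty. Compound 4 is estimated at 3000 nM, within a range of 1000 nM to 9000 nM.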

Compound 4, half-maximal inhibitory concentration: > 5000 nM
Compound 4: a limit, no number (the forecaster's own chance of this, stated with the estimate: 10%); at least 1.6-fold (0.22 log units) between middle value and limit.
By their numbers in this assay, from the lowest: compound 3; then compounds 1 and 2 (each within the scatter of the next). At a limit, above all of these: compound 4.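

In this assay compound 4 gives > 5000 nM, a limit of the assay and not a number. For the compounds shown here, exchanging the whole ring gives an at least 5.0-fold higher number from compound 3 to compound 4 (0.69 log units; beyond the scatter), the first change at this position to move the number upward, whereas the only earlier step, adding fluoro, moved it downward. Dimethylamino in place of bromo gives an at least 2.0-fold higher number from compound 2 to compound 4 (0.30 log units; that floor lies within the scatter), so this single exchange is only bounded from below, and its floor does not by itself separate it from the scatter.

The compounds shown leave open how far the number would rise at this position, and whether the rise follows from losing the bromo group or from bringing in dimethylamino. A primary amine, a methoxy group or a chloro group in the same place would help to tell these apart.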